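Returning selenium to the core: from compound 2 to compound 3

The source may report more compounds than this note shows. Statements on the series, on what has been measured and on what is new or still open speak of the compounds shown alone.

Compound 1 `C[Se]/C(=N\C(=O)c1ccco1)NC(=O)c1ccco1`: 0.05 nM
Compound 2 `CS/C(=N\C(=O)c1ccco1)NC(=O)c1ccco1`: 77100 nM

In a functional assay on HT-29 cells (Homo sapiens) for cytotoxicity, read by MTT assay, with a stated time of 72 h (a higher number here means a weaker inhibitor of growth, a lower number a stronger inhibitor of growth), compound 1 gives 0.05 nM. For the measured compounds named here, compound 2 stands at the highest of the two numbers, and the only step, a 1500000-fold higher number from compound 1 to compound 2 (6.19 log units; beyond the scatter), is the move away from selenium. Compound 3 `O=C(/N=C(/NC(=O)c1ccco1)[Se]Cc1ccccc1)c1ccco1` reverses that move, with a group of 8 heavy atoms (7 carbon, 1 selenium; one six-membered aromatic ring of carbon only) in place of a group of 2 heavy atoms (1 carbon, 1 sulfur; no ring), on a carbon with a double bond to nitrogen. The step bearing on it is a 1500000-fold higher number from compound 1 to compound 2 (6.19 log units; beyond the scatter), and compound 3 is therefore expected to show a large drop in this assay, a 77000-fold lower number from compound 2 to compound 3 (4.89 log units; beyond the scatter). For compound 3 the estimate is 1 nM, with a range of 0.05 nM to 300 nM.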

Compound 3, concentration for 50% growth inhibition: 7190 nM
The estimate for compound 3 lay 7200-fold (3.86 log units) below the measured number; the whole stated range lies below it.
By their numbers in this assay, from the lowest: compound 1; then compound 3; then compound 2.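

In this assay, selenium alone does not bring back the number of compound 1: with selenium kept, phenyl in place of hydrogen on a saturated chain carbon bound to a selenium atom gives a 140000-fold higher number from compound 1 to compound 3 (5.16 log units; beyond the scatter). The exchange of methylsulfanyl for the selenium group carrying the aromatic ring gives only an 11-fold lower number from compound 2 to compound 3 (1.03 log units; beyond the scatter), so the number at this position depends on what selenium carries as well as on the atom itself. Nothing available explains either step.

The compounds shown leave open where an ethyl group or a longer chain on selenium would fall. They also leave open what the same phenyl-bearing carbon on sulfur would give, which would separate the share of the atom from that of the ring.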